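Cyano for methyl on the aryl ring of compound 1

The source may hold more compounds than are shown below. What is called first, only, known or untested is meant among the compounds shown, and "the series" means these compounds.

Compound 1 `COC(=O)/C=C/c1ccc2c(c1)C(=O)C(=O)N2Cc1ccc(C)cc1` holds the lowest of the two numbers given in a functional assay on HT-29 cells (Homo sapiens) for cytotoxicity, read by MTT assay, with a stated time of 48 h (on this read-out higher numbers stand for weaker inhibition and lower numbers for stronger inhibition), where compound 1 gives 30 nM. The nearest number belongs to compound 3 `COC(=O)/C=C/c1ccc2c(c1)/C(=N/O)C(=O)N2Cc1ccc(Br)cc1`, which in this assay gives 3640 nM, a gap beyond the scatter. Compound 2 `CCCCc1ccc2c(c1)C(=O)C(=O)N2` returns no number in this assay but only a limit, > 10000 nM, sitting at the limit of > 10000 nM in this assay, at which 1 of the 3 values shown sits. Within the data shown here, no pair of measured compounds differs in a single place, so no measured step exists to lean on. Compound 4 `COC(=O)/C=C/c1ccc2c(c1)C(=O)C(=O)N2Cc1ccc(C#N)cc1` differs from compound 1 by cyano in place of methyl on an aromatic carbon. Without a measured step of this kind, a change of about the size of the scatter is expected, in either direction. Compound 4 is estimated at 40 nM in this assay, between 10 nM and 200 nM, the expected step being a 1.3-fold higher number from compound 1 to compound 4 (0.12 log units; within the scatter).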

Compound 4, half-maximal inhibitory concentration: 50 nM
Compound 4: the middle estimate sits 1.3-fold (0.10 log units) below what was measured; low and high end bracket the measured number.
By their numbers in this assay, from the lowest: compounds 1 and 4 (each within the scatter of the next); then compound 3. At a limit, above all of these: compound 2.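

Cyano in place of methyl on an aromatic carbon, para to a large group, gives in this assay the first measured step at this position: a 1.7-fold higher number from compound 1 to compound 4 (0.22 log units; within the scatter). The 4-methylphenyl to 4-cyanophenyl difference, which brings in a hydrogen-bond acceptor, therefore leaves the two compounds indistinguishable on this read-out. No measured property shown bears on this step.

On these data alone, whether this position accepts other groups, such as an amine, a carboxylic acid or a longer chain, remains open. A single step also establishes no trend across the position.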